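This account rests on a few compounds, and the source may have more. Where it says the series, first, only, none or still open, it means among the compounds named here.

Measured in a physicochemical assay for solubility, read by chemiluminescence, measured as kinetic solubility; a lower number here means a less soluble compound, a higher number a more soluble compound:
- Compound 1 `O=S(=O)(Nc1ncnc2[nH]nc(O)c12)c1cccc(Cl)c1Cl`: >= 234000 nM, a limit
- Compound 2 `COc1nn(CC(=O)O)c2ncnc(NS(=O)(=O)c3cccc(Cl)c3Cl)c12`: >= 483000 nM, a limit
- Compound 3 `COc1nn(C)c2nc(C)nc(NS(=O)(=O)c3cccc(Cl)c3Cl)c12`: >= 557000 nM, a limit

All three compounds give only limits and no number in this assay, so the series offers no exact value to work from. Compound 3 stands at >= 557000 nM, which is a limit and not a measured number.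

Compound 4 `COc1nn(C)c2nc(NC3COC3)nc(NS(=O)(=O)c3cccc(Cl)c3Cl)c12` differs from compound 3 in one place. It has (oxetan-3-yl)amino in place of methyl on an aromatic carbon, between two ring nitrogen atoms ((oxetan-3-yl)amino in place of methyl on an aromatic carbon).

Going by the values given here, no pair of measured compounds differs in one place, so the size of this change has not been measured. A small downward step in this assay is expected, and the estimated step is an at least 1.8-fold lower number from compound 3 to compound 4 (0.26 log units; that floor lies within the scatter). A further limit rather than a number would also be unsurprising. For compound 4 the estimated value is 300000 nM, with an expected range of 80000 nM to 600000 nM.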

Compound 4, solubility: >= 712000 nM
Compound 4: a limit, no number (the forecaster's own chance of this, stated with the estimate: 60%); at least 2.3-fold (0.37 log units) between middle value and limit.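

In this assay compound 3 gives >= 557000 nM, a limit. Going by these compounds alone, compound 4 gives >= 712000 nM, also a limit, so no step between these two compounds can be read. All four compounds shown give limits, leaving open how far (oxetan-3-yl)amino in place of methyl moves the read-out in this assay.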